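The source may hold more compounds than are shown below. What is called first, only, known or untested is meant among the compounds shown, and "the series" means these compounds.

In an assay on COS-7 cells for inhibition of patatin-like phospholipase domain-containing protein 2 (Mus musculus) (on this read-out lower numbers stand for stronger inhibition and higher numbers for weaker inhibition), compound 3 `CCCCOC(=O)c1cccc(-c2ccc(OCC)cc2)c1` gives 100000 nM. Compound 1 `CCOC(=O)c1cccc(-c2ccsc2)c1` gives 75000 nM in this assay, and these two numbers lie within the usual scatter of each other. For compound 2 `CCOc1ccc(-c2cccc(C(=O)O)c2)cc1` the result in this assay is a limit, > 200000 nM, not a number (the limit of > 200000 nM in this assay, at which 1 of the 3 values shown sits). Among the measured compounds shown here, the only step between measured compounds, an at least 2.0-fold lower number from compound 2 to compound 3 (0.30 log units; that floor lies within the scatter), sits at that floor and is within the scatter.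

Compound 4 `CCNC(=O)c1cccc(-c2ccc(OCC)cc2)c1` differs from compound 3 by ethylamino in place of butoxy on a carbonyl carbon. No measured step exchanges an ester for an amide, so the one step shown offers little guidance. With nothing pointing either way, the step of no change at the digits printed from compound 3 to compound 4 (within the scatter) is expected to stay within the scatter. Compound 4 is therefore estimated at 100000 nM, with a range from 30000 nM to 300000 nM.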

Compound 4, half-maximal inhibitory concentration: 90000 nM
Beside the measured number, compound 4's estimate is 1.1-fold (0.05 log units) above it, within the range that was stated.
By their numbers in this assay, from the lowest: compounds 1, 4 and 3 (each within the scatter of the next). At a limit, above all of these: compound 2.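

Ethylamino and butoxy on this carbonyl carbon cannot be told apart in this assay, so the ester is not required for this level of inhibition: the step is a 1.1-fold lower number from compound 3 to compound 4 (0.05 log units; within the scatter). Ethylamino in place of hydroxy gives the first step beyond the scatter, an at least 2.2-fold lower number from compound 2 to compound 4 (0.34 log units; beyond the scatter). The result for compound 2 is a limit, not a number: the limit of > 200000 nM in this assay, at which 1 of the 4 values shown sits.

Still open, as far as these compounds go, is whether a plain amino group, a longer chain on the amide nitrogen or a ring there would move the number beyond the scatter. Any group on this carbonyl carbon that gives much stronger inhibition also remains to be seen.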